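The source may hold more compounds than are shown below. What is called first, only, known or untested is meant among the compounds shown, and "the series" means these compounds.

Measured compounds:
compound 1, `CC[C@@H](C)[C@H](NC(=O)c1ccc(C(CC)(CC)c2ccc(OCC(O)C(C)(C)C)c(C)c2)n1CC)C(=O)OC`, giving 26 nM in an assay on HL-60 cells for agonist activity at vitamin D3 receptor (Homo sapiens), read by microscopy, with a stated time of 96 h; a lower number here means that less compound is needed, a higher number that more compound is needed for the effect
compound 2, `CC[C@@H](C)[C@H](NC(=O)c1ccc(C(CC)(CC)c2ccc(OCC(O)C(C)(C)C)c(C)c2)n1CC)C(=O)O`, giving 2.3 nM in this assay

Going by the values given here, compound 2 stands at the lowest number of the two measured; its nearest neighbour is compound 1, and the single measured step, an 11-fold lower number from compound 1 to compound 2 (1.05 log units; beyond the scatter), is large and lies well beyond the scatter. Compound 3, `CCn1c(C(=O)OCc2ccccn2)ccc1C(CC)(CC)c1ccc(OCC(O)C(C)(C)C)c(C)c1`, is not yet measured. Its change from compound 2 reads ((pyridin-2-yl)methoxy in place of (1-carboxy-2-methylbutyl)amino on a carbonyl carbon). Among the compounds with values here, the only step that bears on it is an 11-fold lower number from compound 1 to compound 2 (1.05 log units; beyond the scatter), where freeing the carboxylic acid gave the large drop in the number. In compound 3 that carboxy group leaves altogether, together with the amide hydrogen, and the entering (pyridin-2-yl)methoxy brings no hydrogen-bond donor at all. Within the data shown here, no measured compound lacks the amino-acid fragment, so the size of the effect is uncertain, but the direction is expected to be upward. For compound 3 in this assay the expected number is 30 nM, within 7 nM to 130 nM, which as a step is expected to be a 13-fold higher number from compound 2 to compound 3 (1.12 log units; beyond the scatter).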

Compound 3, half-maximal effective concentration: > 50000 nM
Compound 3 ended at the assay's limit; the forecaster's own chance of this, stated with the estimate: 5%; middle value at least 1600-fold (3.22 log units) away from the limit.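

In this assay compound 3 gives no number, only a limit: the limit of > 50000 nM in this assay, at which 1 of the 3 values shown sits.

Until now this carbonyl carbon had carried only the amino-acid fragment, varied at its far end, and replacing that whole fragment with (pyridin-2-yl)methoxy gives an at least 21000-fold higher number from compound 2 to compound 3 (4.33 log units; beyond the scatter), a step that rests on the limit. The comparison with the methyl ester adds a second point, with an at least 1900-fold higher number from compound 1 to compound 3 (3.28 log units; beyond the scatter), also resting on the limit: compound 1 has no free carboxy group yet still gives a measurable value, so absence of the free acid alone does not account for the result in compound 3.

The compounds shown leave open which part of the change carries the loss, since the amide hydrogen, the 2-methylbutyl chain and the carboxy group all leave while the pyridine ring enters in one step. A (pyridin-2-yl)methylamino group on the same carbonyl carbon would keep the amide hydrogen with the same ring, and a glycine fragment would keep the carboxylic acid without the 2-methylbutyl chain, so each would separate these parts.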